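Thiocarbamate Chain Exchanged for a Benzyl Carbamate

The source may hold more compounds than are shown below. What is called first, only, known or untested is meant among the compounds shown, and "the series" means these compounds.

Compound 1 `CNC(=O)OC[C@H]1OC(n2cnc3c(NC4CCOC4)nc(Cl)nc32)[C@H](O)[C@@H]1O`: 96 nM
Compound 2 `CC/N=C(\S)OC[C@H]1OC(n2cnc3c(NC4CCOC4)ncnc32)[C@H](O)[C@@H]1O`: 33 nM
Compound 3 `CCCC/N=C(\S)OC[C@H]1OC(n2cnc3c(NC4CCOC4)ncnc32)[C@H](O)[C@@H]1O`: 157 nM

In an assay on DDT1 cells (Cricetulus griseus) for binding affinity to adenosine receptor A1 (Homo sapiens), read by radioligand binding (a higher number here means a weaker inhibitor, a lower number a stronger inhibitor), compound 3 gives the highest of the three numbers. Compound 1 stands within the scatter of it, while compound 2 lies furthest away: a 4.8-fold higher number from compound 2 to compound 3 (0.68 log units; beyond the scatter).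

Compound 4 `O=C(NCc1ccccc1)OC[C@H]1OC(n2cnc3c(NC4CCOC4)ncnc32)[C@H](O)[C@@H]1O` differs from compound 3 in one place: a group of 10 heavy atoms (8 carbon, 1 nitrogen, 1 oxygen; one six-membered aromatic ring of carbon only) in place of a group of 7 heavy atoms (5 carbon, 1 nitrogen, 1 sulfur; no ring), on an oxygen on a saturated carbon.

Going by the values given here, only one measured step touches this change, a 4.8-fold higher number from compound 2 to compound 3 (0.68 log units; beyond the scatter), and it concerns a longer chain, not a ring or a carbamate in place of a thiocarbamate. Among the compounds with values here, no measured pair shows that exchange. Because a 4.8-fold higher number from compound 2 to compound 3 (0.68 log units; beyond the scatter) was modest and does not cover the change, the expected step of a 1.3-fold lower number from compound 3 to compound 4 (0.12 log units; within the scatter) is none beyond the scatter. Compound 4 is therefore estimated at 120 nM, within 40 nM to 400 nM.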

Compound 4, inhibition constant: 1830 nM
Beside the measured number, compound 4's estimate is 15-fold (1.18 log units) below it; measured number above the stated range.
By their numbers in this assay, from the lowest: compound 2; then compounds 1 and 3 (each within the scatter of the next); then compound 4.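

On this oxygen, the change reaches well past the modest effect of chain length seen so far: in this assay benzylcarbamoyl gives a 12-fold higher number from compound 3 to compound 4 (1.07 log units; beyond the scatter) and also a 55-fold higher number from compound 2 to compound 4 (1.74 log units; beyond the scatter) in the same direction. The exchange brings in an aromatic ring and puts oxygen where sulfur stood, so these steps cannot separate the two changes. Nothing available explains the rise in the number.

On these data alone, it remains open whether a butylcarbamoyl group, which joins the chain of compound 3 to the oxygen of compound 4, would stand nearer compound 3 or compound 4.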